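A few compounds are considered here, and "the series" means these few. Any claim that something is new, unique, unknown or untested is made for them only; others in the source may bear on it.

Of the compounds shown here, two from this study have been measured in a functional assay on the whole organism (strain Wistar albino) for inhibition, with Rattus norvegicus as the target, read by paw edema, with a stated time of 1 h, at a dose of 40 mg/kg by the oral route; a higher number here means more inhibition at the dose given (going by the name of the read-out), a lower number less inhibition. Compound 1 `Cc1ccc(N2C(=O)CSC2c2sc(Cc3ccc(Cl)cc3)nc2C)cc1` gives 59.9% in this assay. Compound 2 `COc1ccc(N2C(=O)CSC2c2sc(-c3ccccc3)nc2C)cc1` gives 52.3%, the lower of the two numbers, though the gap to compound 1 lies within the scatter, so the two cannot be ranked against each other. Compound 3 `COc1ccc(N2C(=O)CSC2c2sc(Cc3ccc(Cl)cc3)nc2C)cc1` has not yet been measured. It differs from compound 2 in one place: 4-chlorobenzyl in place of phenyl on an aromatic carbon. Compound 1 carries that same 4-chlorobenzyl group and, with 59.9%, stands within the scatter of compound 2, so nothing in the two numbers points to a step beyond the scatter for this change. The expected step is a number 4.7 percentage points higher from compound 2 to compound 3 (within the scatter), upward but small. Compound 3 is estimated to reach about 57%, with a range from 47% to 67%.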

Compound 3, a percentage reported as inhibition, in the whole organism at one dose (the size of the read-out at that dose, not a potency): 20.9%
The estimate for compound 3 lay 36.1 percentage points above the measured number; measured number below the stated range.
By their numbers in this assay, from the lowest: compound 3; then compounds 2 and 1 (each within the scatter of the next).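

Swapping phenyl for 4-chlorobenzyl on the aromatic carbon next to the ring nitrogen and the ring sulfur is no harmless change in this assay, since it gives a number 31.4 percentage points lower from compound 2 to compound 3 (beyond the scatter) when methoxy is present on the other aromatic ring. With 4-chlorobenzyl held in place, methoxy in place of methyl on an aromatic carbon gives a number 39 percentage points lower from compound 1 to compound 3 (beyond the scatter), so good inhibition with 4-chlorobenzyl is seen with methyl but not with methoxy. No measurement shown here explains this drop.

The compounds shown leave open whether the loss follows the chlorine atom or the extra carbon that links the ring, which a plain benzyl group at the same place could help to separate. Also open, going by these compounds, is how an amine or a hydroxyl group would fare in place of the methoxy.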